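The source may report more compounds than this note shows. Statements on the series, on what has been measured and on what is new or still open speak of the compounds shown alone.

Measured so far:
compound 1, `CN(C)C(=O)c1cc2cnc(Nc3ccc(NC(=O)C4(C(=O)Nc5ccccc5F)CC4)cc3)nc2n1C1CCCC1`, 28.2% in a functional assay on NCI-H460 cells (Homo sapiens) for inhibition, read by CCK-8 assay, with a stated time of 72 h, tested at 1 uM; a higher number here means more inhibition of growth at the concentration tested, a lower number less inhibition of growth
compound 2, `CN(C)C(=O)c1cc2cnc(Nc3ccc(NC(=O)C4(C(=O)Nc5cccc(O)c5)CC4)cc3)nc2n1C1CCCC1`, 75.5% in this assay
compound 3, `CN(C)C(=O)c1cc2cnc(Nc3ccc(NC(=O)C4(C(=O)Nc5ccc(Cl)c(C(F)(F)F)c5)CC4)cc3)nc2n1C1CCCC1`, 2.1% in this assay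

Compound 3 stands lowest of the three: compound 1 sits a number 26.1 percentage points lower from compound 1 to compound 3 (beyond the scatter), and compound 2 sits a number 73.4 percentage points lower from compound 2 to compound 3 (beyond the scatter). The next compound, compound 4 `CN(C)C(=O)c1cc2cnc(Nc3ccc(NC(=O)C4(C(=O)Nc5ccc(O)cc5)CC4)cc3)nc2n1C1CCCC1`, differs from compound 3 in one place: 4-hydroxyphenyl in place of 4-chloro-3-(trifluoromethyl)phenyl on an amide-type nitrogen. Within the data shown here, the step that bears most closely on this is the one where a hydroxyphenyl group replaced the 4-chloro-3-(trifluoromethyl)phenyl group, read backwards from compound 2 to compound 3, which was large. Moving in the opposite direction, a large rise in this assay is therefore expected for compound 4, estimated as a number 59.9 percentage points higher from compound 3 to compound 4 (beyond the scatter), landing near compound 2. The expected value for compound 4 is 62%, within 35% to 85%.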

Compound 4, percent growth inhibition at one concentration: 90.4%
Beside the measured number, compound 4's estimate is 28.4 percentage points below it; measured number above the stated range.
By their numbers in this assay, from the lowest: compound 3; then compound 1; then compound 2; then compound 4.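

Even with a hydroxyl kept on the phenyl ring, the choice between 3-hydroxyphenyl and 4-hydroxyphenyl on the amide-type nitrogen still matters in this assay, with a number 14.9 percentage points higher from compound 2 to compound 4 (beyond the scatter). The 4-hydroxyphenyl group also stands well clear of the two halogen-bearing groups, with a number 62.2 percentage points higher from compound 1 to compound 4 (beyond the scatter) and a number 88.3 percentage points higher from compound 3 to compound 4 (beyond the scatter), which puts compound 4 highest of the four. No measurement given here explains these gaps. From the compounds shown here alone, it remains open whether a 4-methoxyphenyl or 4-aminophenyl group on this nitrogen would hold that level.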